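This account rests on a few compounds, and the source may have more. Where it says the series, first, only, none or still open, it means among the compounds named here.

Measured in a toxicity assay on MCF-10A cells (Homo sapiens) for inhibition, read by MTT assay, with a stated time of 72 h; a higher number here means a weaker inhibitor of growth, a lower number a stronger inhibitor of growth:
- compound 1 `COc1cccc(CNCCCNS(=O)(=O)c2cc(C(F)(F)F)cc(C(F)(F)F)c2)c1`: 6600 nM
- compound 2 `O=S(=O)(NCCCNCc1cccc(Cl)c1)c1cc(C(F)(F)F)cc(C(F)(F)F)c1`: 7000 nM
- compound 3 `O=S(=O)(NCCCNCc1ccccc1Cl)c1cc(C(F)(F)F)cc(C(F)(F)F)c1`: 11000 nM

Compound 3 gives the highest of the three numbers, but the step of a 1.7-fold higher number from compound 1 to compound 3 (0.22 log units; within the scatter) and the step of a 1.6-fold higher number from compound 2 to compound 3 (0.20 log units; within the scatter) are both within the scatter, as is a 1.1-fold higher number from compound 1 to compound 2 (0.03 log units; within the scatter), so the three compounds cannot be ranked against each other; the series is flat as far as it has been measured.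

Compound 4 `CN(CCCNS(=O)(=O)c1cc(C(F)(F)F)cc(C(F)(F)F)c1)Cc1ccccc1` is the next member. Relative to compound 3 the change is benzyl(methyl)amino in place of (2-chlorobenzyl)amino on a saturated chain carbon, three bonds along the chain from a sulfonamide nitrogen. The measured steps all concern the substituent on the benzyl ring while the amine nitrogen kept its hydrogen; none of them touches the amine nitrogen itself, so none bears directly on the methyl that enters here. What they do show is that exchanging chloro for methoxy, or moving the chloro around the ring, produced no step beyond the scatter. Within the data shown here, the loss of the chloro in compound 4 is therefore expected to matter little, and there is no measured precedent for the methyl. The expectation is a number near that of compound 3, with the step of a 1.2-fold lower number from compound 3 to compound 4 (0.09 log units; within the scatter) within the scatter and the range widened for the untested methyl. Compound 4 is estimated at 9000 nM in this assay, between 3500 nM and 23000 nM.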

Compound 4, concentration for 50% growth inhibition: 26000 nM
Beside the measured number, compound 4's estimate is 2.9-fold (0.46 log units) below it, and the stated range ends below it.
By their numbers in this assay, from the lowest: compounds 1, 2 and 3 (each within the scatter of the next); then compound 4.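

In this assay, among these compounds, the amine end of the chain gives the first steps beyond the scatter: a 2.4-fold higher number from compound 3 to compound 4 (0.37 log units; beyond the scatter), a 3.7-fold higher number from compound 2 to compound 4 (0.57 log units; beyond the scatter) and a 3.9-fold higher number from compound 1 to compound 4 (0.60 log units; beyond the scatter), each modest, whereas the ring changes among compound 1, compound 2 and compound 3 produced no such step. All three steps run the same way, with benzyl(methyl)amino giving the higher number and so the weaker inhibition of growth, and none of the four compounds goes against this; the change also takes the group from 1 hydrogen-bond donor to 0. No measurement shown accounts for this shift.

Each of these steps adds the methyl and alters the ring substituent at once, so the compounds shown leave open which of the two changes carries the shift. A plain benzylamino group and a (2-chlorobenzyl)(methyl)amino group would separate the two, and an ethyl group on the amine nitrogen would show whether the outcome extends beyond methyl.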